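A Smaller Amide in Place of a Ring Carbonyl

The compounds below may be only part of what the source reports. "The series", "measured", "known", "first", "only" and "open" are said of these compounds alone.

compound 1 `Cc1cc(C)c(S(=O)(=O)N2CCC(C(=O)N3CCC(C)CC3)CC2)c(C)c1`: > 5000 nM
compound 2 `CC1CCN(C2CCN(S(=O)(=O)c3ccc(-c4ccc(Cl)cc4)cc3)CC2)CC1`: 105 nM

Of the compounds shown here, two have been measured. In a functional assay on DLD-1 cells (Homo sapiens) for antiproliferative activity, read by CellTiter-Glo, with a stated time of 72 h (a lower number here means a stronger inhibitor, a higher number a weaker inhibitor), compound 1 gives > 5000 nM, and this value is a limit of the assay rather than a number. Compound 1 therefore stands at the limit of > 5000 nM in this assay, at which 1 of the 2 values shown sits, so only a floor for its weakness is known. In this assay compound 2 gives 105 nM. Within the data shown here, no step between measured compounds is known, since the two structures differ in more than one place.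

Compound 3 `CCCC(=O)NC1CCN(S(=O)(=O)c2c(C)cc(C)cc2C)CC1` is not yet measured. It differs from compound 1 as follows: (propylcarbonyl)amino in place of (4-methylpiperidin-1-yl)carbonyl on a saturated ring carbon. Among the measured compounds shown here, with no measured step to lean on, the step from compound 1 to compound 3 is expected to be a step that the limit leaves unreadable from compound 1 to compound 3, which is none beyond the usual scatter. Compound 3 is therefore expected to give 8000 nM in this assay, most likely between 2000 nM and 40000 nM.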

Compound 3, half-maximal inhibitory concentration: > 5000 nM
Compound 3 was reported as a limit; the forecaster's own chance of this, stated with the estimate: 70%; the middle value is on the limit's open side.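

Compound 1 and compound 3 are both reported only as a limit of the assay, not as a number, so no step between them can be read: the limit of > 5000 nM in this assay, at which 2 of the 3 values shown sit.

The compounds shown leave open how strongly either compound acts, and whether (propylcarbonyl)amino in place of (4-methylpiperidin-1-yl)carbonyl on a saturated ring carbon changes the activity at all.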